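The compounds below may be only part of what the source reports. "The series", "measured", "known", "first", "only" and "open" are said of these compounds alone.

Compound 1 `COc1cc2ncnc(Nc3ccc(Cl)c(C(F)(F)F)c3)c2cc1OCCCN1CCNCCNCCNCC1` and compound 2 `COc1cc2ncnc(Nc3cccc(C(F)(F)F)c3)c2cc1OCCCN1CCNCCNCCNCC1` share one core and differ in a single spot: hydrogen in place of chloro on an aromatic carbon. In a functional assay on A-431 cells (Homo sapiens) for antiproliferative activity, read by MTT assay, with a stated time of 72 h (on this read-out lower numbers stand for stronger inhibition and higher numbers for weaker inhibition), compound 1 gives 1710 nM, and compound 2 gives 1950 nM, so that change brought a 1.1-fold higher number from compound 1 to compound 2 (0.06 log units; within the scatter). Compound 3 `COc1cc2ncnc(Nc3ccc(Cl)c(C(F)(F)F)c3)c2cc1OCCCN1CCNCCNCC1` carries a different core, set apart from compound 1 by a group of 9 heavy atoms (6 carbon, 3 nitrogen; one nine-membered non-aromatic ring with 3 hetero atoms) in place of a group of 12 heavy atoms (8 carbon, 4 nitrogen; one twelve-membered non-aromatic ring with 4 hetero atoms), on a saturated chain carbon, three bonds along the chain from an oxygen on an aromatic ring; in this assay compound 3 gives 2980 nM, which is a 1.7-fold higher number from compound 1 to compound 3 (0.24 log units; within the scatter). Compound 4 `COc1cc2ncnc(Nc3cccc(C(F)(F)F)c3)c2cc1OCCCN1CCNCCNCC1` has not yet been measured. It stands to compound 3 as compound 2 stands to compound 1: hydrogen in place of chloro on an aromatic carbon, at the same place in both pairs, so this is the same change made once more on the other core. Because the earlier step was a 1.1-fold higher number from compound 1 to compound 2 (0.06 log units; within the scatter), a step of similar size is expected here, a 1.1-fold higher number from compound 3 to compound 4 (0.04 log units; within the scatter). Compound 4 is therefore estimated at 3300 nM in this assay, most likely between 1600 nM and 6800 nM.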

Compound 4, half-maximal inhibitory concentration: 1560 nM
Compound 4: the middle estimate sits 2.1-fold (0.33 log units) above what was measured; the measured number lies below the stated range.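

In this assay, hydrogen in place of chloro on the core with the nine-membered ring gave a 1.9-fold lower number from compound 3 to compound 4 (0.28 log units; within the scatter), and this step does not differ beyond the scatter from the same change on the core of compound 1: the same change on two cores in this assay, a 1.1-fold higher number (0.06 log units; within the scatter) from compound 1 to compound 2 and a 1.9-fold lower number (0.28 log units; within the scatter) from compound 3 to compound 4, 2.2-fold (0.34 log units) apart, within the scatter of two such steps

The ring change, made on the compounds without chloro, gave a 1.3-fold lower number from compound 2 to compound 4 (0.10 log units; within the scatter), and it too stays within the scatter of its earlier counterpart: the same change on two cores in this assay, a 1.7-fold higher number (0.24 log units; within the scatter) from compound 1 to compound 3 and a 1.3-fold lower number (0.10 log units; within the scatter) from compound 2 to compound 4, 2.2-fold (0.34 log units) apart, within the scatter of two such steps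

So neither change can be said to behave differently on the two cores, but with every step this small and only one pair for each comparison, this does not prove that either effect carries over.

The compounds shown leave open what a bromo group or a nitrile in place of the chloro would do. They also leave open whether a longer chain to the ring would give a step beyond the scatter.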